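Loss of a ring hydroxy in a fused pentacyclic lactone series

A few compounds are considered here, and "the series" means these few. Any claim that something is new, unique, unknown or untested is made for them only; others in the source may bear on it.

Measured so far:
compound 1 `Cc1cc(=O)cc2c3c1[C@@H](O)[C@H]1[C@@H]3[C@]3(CC2)C(=O)O[C@@H]1CC3C` — 10300 nM
compound 2 `Cc1cc(=O)cc2c3c1C[C@@H]1[C@@H]4OC(=O)[C@](C[C@H]2O)(C(C)C4O)[C@H]31` — 25400 nM
compound 3 `Cc1cc(=O)cc2c3c1[C@H](O)[C@@H]1[C@@H]4OC(=O)[C@](CC2)(C(C)C4O)[C@H]31` — 2400 nM

In a functional assay on A549 cells (Homo sapiens) for inhibition, read by CCK-8 assay, with a stated time of 72 h (a lower number here means a stronger inhibitor, a higher number a weaker inhibitor), compound 3 gives 2400 nM, the lowest of the three numbers. Compound 1 gives 10300 nM and compound 2 gives 25400 nM; both gaps to compound 3 are beyond the scatter, so compound 3 is the strongest inhibitor among the measured set.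

Compound 4 `Cc1cc(=O)cc2c3c1[C@H](O)[C@H]1[C@@H]3[C@]3(CC2)C(=O)O[C@@H]1CC3C` is not yet measured. It differs from compound 3 in one place: hydrogen in place of hydroxy on a saturated ring carbon. Going by the values given here, no measured pair shows a step of this kind, so the size is open. Removal of a hydroxy from the saturated ring is expected to cost some potency; the step of a 2.1-fold higher number from compound 3 to compound 4 (0.32 log units; beyond the scatter) is expected to be small, near the scatter. Compound 4 is therefore estimated at 5000 nM, within 1500 nM to 16000 nM.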

Compound 4, half-maximal inhibitory concentration: 2400 nM
For compound 4 the middle estimate is 2.1-fold (0.32 log units) above the measured one, within the range that was stated.
By their numbers in this assay, from the lowest: compounds 3 and 4 (each within the scatter of the next); then compound 1; then compound 2.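

Hydrogen in place of hydroxy on a saturated ring carbon gives no change at the digits printed from compound 3 to compound 4 (within the scatter) in this assay, so this hydroxy is not required to hold the number at this level. By contrast, a stereocentre at a saturated ring carbon drawn S rather than R accompanies a 4.3-fold lower number from compound 1 to compound 4 (0.63 log units; beyond the scatter). That second step carries a caution: the fact that one of compounds 1 and 4 is drawn with a defined configuration and the other without, at the place where they differ

On these data alone, whether a methoxy, an amine or a longer chain on the saturated ring carbon would shift the number remains open. Also open, as far as these compounds go, is whether the hydroxy step would be the same with the stereocentre drawn S.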